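Dropping the amide: a direct aryl link at the pyridine

The compounds below may be only part of what the source reports. "The series", "measured", "known", "first", "only" and "open" are said of these compounds alone.

Of the compounds shown here, three sharing one core have been measured in an assay on isolated protein for inhibition of alkaline phosphatase, tissue-nonspecific isozyme (Homo sapiens); on this read-out lower numbers stand for stronger inhibition and higher numbers for weaker inhibition. Compound 2 `COc1ccc(Cl)cc1S(=O)(=O)Nc1cncc(C(N)=O)c1` gives 16 nM, compound 1 `COc1ccc(Cl)cc1S(=O)(=O)Nc1cncc(C(=O)Nc2ccccc2)c1` gives 310 nM, and compound 3 `COc1ccc(Cl)cc1S(=O)(=O)Nc1cncc(C(=O)N2CCN(C)CC2)c1` gives 671 nM, which is the highest number of the three. The steps into compound 3 were both upward: a 2.2-fold higher number from compound 1 to compound 3 (0.34 log units; beyond the scatter) and a 42-fold higher number from compound 2 to compound 3 (1.62 log units; beyond the scatter), so the group on the carbonyl carbon clearly matters. Compound 4 `COc1ccc(Cl)cc1S(=O)(=O)Nc1cncc(-c2ccc(C)cc2)c1` now changes that region differently: 4-methylphenyl in place of (4-methylpiperazin-1-yl)carbonyl on an aromatic carbon. Among the compounds with values here, the carbonyl itself disappears, and no measured step shows what that does; the two steps above only show that a small group on the carbonyl gave the lowest number and a bulky amine gave the highest. In this assay compound 4 is therefore expected to land roughly where compound 1 sits, that is a 2.2-fold lower number from compound 3 to compound 4 (0.35 log units; beyond the scatter), with wide uncertainty. The estimate for compound 4 in this assay is 300 nM, within a range from 60 nM to 1500 nM.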

Compound 4, half-maximal inhibitory concentration: 147 nM
Beside the measured number, compound 4's estimate is 2.0-fold (0.31 log units) above it; the range from low to high includes it.
By their numbers in this assay, from the lowest: compound 2; then compound 4; then compound 1; then compound 3.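

In this assay, the carbonyl is not needed for a number in this range: joining 4-methylphenyl directly to the aromatic carbon gives a 4.6-fold lower number from compound 3 to compound 4 (0.66 log units; beyond the scatter) and a 2.1-fold lower number from compound 1 to compound 4 (0.32 log units; beyond the scatter) as well. Both amides with a large group on the nitrogen therefore sit higher than this carbonyl-free compound, although the small carbamoyl group still gives the lowest number of the set, with a 9.2-fold higher number from compound 2 to compound 4 (0.96 log units; beyond the scatter) in the upward direction. Nothing measured here explains these differences.

The compounds shown leave open whether the methyl on the 4-methylphenyl ring contributes anything, and how an unsubstituted phenyl or a short alkyl chain at this carbon would compare. On these data alone, it is also open whether a carbamoyl group or a carboxylic acid on that aromatic ring would bring the number closer to that of compound 2.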